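A few compounds are considered here, and "the series" means these few. Any claim that something is new, unique, unknown or untested is made for them only; others in the source may bear on it.

Compound 1 `CNC(=O)c1cc(C)n(Cc2cc(Cl)ccc2OCc2ccccc2)n1` is recorded in a physicochemical assay for lipophilicity, at pH 7.4 (a lower number here means a more polar compound, a higher number a more lipophilic compound), only as a limit, > 3.7. This is also (the limit of > 3.7 in this assay, at which 2 of the 3 values shown sit), so the position of compound 1 within the set is known only from above. Compound 2 `Cc1cc(C(=O)Nc2ccc(F)cc2)nn1Cc1cc(Cl)ccc1OCc1ccccc1` gives 3 in this assay. Compound 3 `Cc1cc(NC(=O)C2CCCO2)nn1Cc1cc(Cl)ccc1OCc1ccccc1` is again reported in this assay only as a limit, > 3.7.

The step to compound 4 `Cc1cc(NC(=O)c2ccccc2)nn1Cc1cc(Cl)ccc1OCc1ccccc1` is benzamido in place of methylcarbamoyl on an aromatic carbon. Among the measured steps, the one nearest in kind is a number at least 0.70 log units lower from compound 1 to compound 2 (beyond the scatter), where an aromatic ring likewise came in at the amide. The group entering compound 4 is an amide of the same orientation as in compound 3, and a number at least 0.70 log units higher from compound 2 to compound 3 (beyond the scatter) shows that orientation moving upward from the measured number of compound 2, whereas a step that the two limits leave unreadable from compound 1 to compound 3 stays unreadable between two limits. One step points down from compound 1, one points up toward the limit, and the starting point itself is a limit. Compound 4 is therefore expected to remain at or near the limit, with the step that the limit leaves unreadable from compound 1 to compound 4 expected to be small or not readable. The estimate for compound 4 in this assay is 3.9, with a range from 3.3 to 4.5, and a limit rather than a number is the more likely outcome.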

Compound 4, distribution coefficient: > 3.7
Compound 4: only a limit was reported; the forecaster's own chance of this, stated with the estimate: 65%; the middle value lies beyond the limit too.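

In this assay compound 4 is recorded only as a limit, > 3.7. Benzamido in place of (4-fluorophenyl)carbamoyl gives a number at least 0.70 log units higher from compound 2 to compound 4 (beyond the scatter), the second step of this kind after a number at least 0.70 log units higher from compound 2 to compound 3 (beyond the scatter), so two different acyl groups on the amino nitrogen at this aromatic carbon now lie clear of the single measured number in the set. Compound 1, with methylcarbamoyl there, goes against a pattern that follows amide orientation alone. Compound 1 is also recorded only as a limit. The steps among compound 1, compound 3 and compound 4 cannot be read, and the series is now mostly bounded rather than measured: the limit of > 3.7 in this assay, at which 3 of the 4 values shown sit.

The step to compound 4 reverses the amide and removes the fluorine together, so the compounds shown do not separate the 4-fluorophenyl group from the orientation of the amide as the source of the lower number at compound 2, and the order among the three limits stays unknown. From the compounds shown here alone, whether an amine or a carboxylic acid in place of phenyl on the carbonyl carbon would bring a reading inside the range of the assay also remains open.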